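A few compounds are considered here, and "the series" means these few. Any claim that something is new, unique, unknown or untested is made for them only; others in the source may bear on it.

Compound 1 `CC(C)Cc1ccc(-c2ccc3c(c2)C(=O)N(C2CCC(=O)NC2=O)C3=O)cc1` and compound 2 `CC(C)Cc1ccc(-c2cccc3c2C(=O)N(C2CCC(=O)NC2=O)C3=O)cc1` are closely related and carry the same groups on the same shared core. In a functional assay on Jurkat cells (Homo sapiens) for activation, read by flow cytometry, with a stated time of 24 h, tested at 10 uM (on this read-out lower numbers stand for a weaker effect and higher numbers for a stronger effect at the one concentration tested), compound 1 gives 7%, and compound 2 gives 7%; the two values are level within the scatter, so neither can be called the more active. Compound 3 `CC(C)Oc1ccc(-c2ccc3c(c2)C(=O)N(C2CCC(=O)NC2=O)C3=O)cc1` has not yet been measured. It differs from compound 1 in one place: isopropoxy in place of isobutyl on an aromatic carbon. Going by the values given here, no measured pair shows this particular change, so there is no step to lean on, and both measured values sit low on the scale. In this assay the step is expected to be small, with no direction beyond the scatter, and is estimated as a number 1 percentage points higher from compound 1 to compound 3 (within the scatter). Compound 3 is therefore estimated to give 8%, with a range from 0% to 22%.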

Compound 3, a percentage reported as activity, at one concentration (the size of the read-out at that concentration, not a potency): 12%
The estimate for compound 3 lay 4 percentage points below the measured number, and the stated range covers the measured number.
By their numbers in this assay, from the lowest: compounds 1, 2 and 3 (each within the scatter of the next).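

In this assay, the exchange of isobutyl for isopropoxy on an aromatic carbon para to a large group gives a number 5 percentage points higher from compound 1 to compound 3 (within the scatter). Going by these compounds alone, this is the first step read at this position, and it shows that an oxygen-linked group with one hydrogen-bond acceptor, at the same count of heavy atoms, leaves the read-out within the scatter of the isobutyl compound. No measured information on these compounds accounts for the size of this step.

Still open, from the compounds shown here alone, is whether an amine, a carboxylic acid or a longer chain at this place would give a read-out beyond the scatter of compound 1. Also open, going by these compounds, is whether isopropoxy would give a similar step on compound 2, where the substituted aromatic ring is attached elsewhere on the shared core.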